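Swapping the aryl group on the hydrazone of compound 2

The source may report more compounds than this note shows. Statements on the series, on what has been measured and on what is new or still open speak of the compounds shown alone.

Measured so far:
- compound 1, `COc1cc2c(Oc3ccc(NC(=O)N/N=C/c4ccc(Cl)cc4Cl)cc3F)ccnc2cc1OCCCN1CCCCC1`, gives 370 nM
- compound 2, `COc1ccc(/C=N/NC(=O)Nc2ccc(Oc3ccnc4cc(OCCCN5CCCCC5)c(OC)cc34)c(F)c2)c(OC)c1`, gives 1600 nM

Both were tested in a functional assay on HT-29 cells (Homo sapiens) for cytotoxicity, read by MTT assay, with a stated time of 72 h; on this read-out lower numbers stand for stronger inhibition and higher numbers for weaker inhibition. Going by the values given here, compound 2 stands at the highest of the two numbers, its only neighbour being compound 1, which sits lower by the step of a 4.3-fold higher number from compound 1 to compound 2 (0.64 log units; beyond the scatter). Compound 3, `C=CCc1cccc(/C=N/NC(=O)Nc2ccc(Oc3ccnc4cc(OCCCN5CCCCC5)c(OC)cc34)c(F)c2)c1OC`, has not yet been measured. It differs from compound 2 in one place: 3-allyl-2-methoxyphenyl in place of 2,4-dimethoxyphenyl on a carbon with a double bond to nitrogen. Among the compounds with values here, only one measured step bears on this kind of change, the exchange of the aryl group on the same carbon between compound 1 and compound 2, which moved the number by a 4.3-fold higher number from compound 1 to compound 2 (0.64 log units; beyond the scatter). That step shows this position can shift the read-out beyond the scatter, but it does not say which way a third group will go, since compound 3 keeps one methoxy group and adds an allyl group rather than returning to the chlorines. The expected step from compound 2 to compound 3 is therefore small and uncertain, a 1.3-fold lower number from compound 2 to compound 3 (0.12 log units; within the scatter). For compound 3 the estimated value is 1200 nM, with a range from 400 nM to 3600 nM.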

Compound 3, half-maximal inhibitory concentration: 460 nM
Estimate against measurement, compound 3: 2.6-fold (0.42 log units) above; measured number inside the range.
By their numbers in this assay, from the lowest: compounds 1 and 3 (each within the scatter of the next); then compound 2.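

In this assay, the earlier pair showed only that 2,4-dimethoxyphenyl on this carbon gave a higher number than 2,4-dichlorophenyl, but the new result shows that a ring carrying a methoxy group can also give a low number: 3-allyl-2-methoxyphenyl in place of 2,4-dimethoxyphenyl gives a 3.5-fold lower number from compound 2 to compound 3 (0.54 log units; beyond the scatter). Set against 2,4-dichlorophenyl, the same group gives a 1.2-fold higher number from compound 1 to compound 3 (0.09 log units; within the scatter), so these two groups cannot be told apart on this read-out, and a ring without chlorine can match the chlorinated one. Nothing measured here explains why the number moves with these groups.

The compounds shown leave open whether the allyl group itself accounts for the step, as its arrival and the loss of one methoxy group come together in a single change, and a ring differing from compound 2 in only one of these respects would be needed to separate them. Going by these compounds, it also remains open how a ring carrying a propyl group or an amine at this place would read in this assay.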